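Azetidine-bearing ether in place of ethoxy: series notes

The compounds below may be only part of what the source reports. "The series", "measured", "known", "first", "only" and "open" are said of these compounds alone.

Measured so far:
compound 1 `CNC(=O)c1cc(-c2ccc(NS(=O)(=O)c3cccc(Cl)c3Cl)cc2)nc2[nH]ncc12` — 4 nM
compound 2 `CCOc1nc(-c2ccc(NS(=O)(=O)c3cc(Cl)ccc3F)cc2)nc2[nH]nc(C)c12` — 23 nM

In an assay for inhibition of serine/threonine-protein kinase Sgk1 (Homo sapiens), with stated times of 30 min and 60 min, in the presence of a further agent that is not named here (on this read-out higher numbers stand for weaker inhibition and lower numbers for stronger inhibition), compound 1 gives 4 nM and compound 2 gives 23 nM; compound 2 thus holds the higher of the two numbers, and the gap to compound 1 lies beyond the scatter. Compound 3 `Cc1n[nH]c2nc(-c3ccc(NS(=O)(=O)c4cc(Cl)ccc4F)cc3)nc(OCC3CN(C(C)C)C3)c12` differs from compound 2 by 1-isopropylazetidin-3-yl in place of methyl on a saturated chain carbon bound to an oxygen on an aromatic ring. Going by the values given here, no measured pair shows this change, so its effect in this assay is open; a step within the scatter, with no clear direction, is expected. Compound 3 is estimated at 20 nM (range 7 nM to 60 nM). The expected step is a 1.2-fold lower number from compound 2 to compound 3 (0.06 log units; within the scatter).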

Compound 3, half-maximal inhibitory concentration: 1 nM
Compound 3: middle estimate off by 20-fold (1.30 log units), on the high side; measured number outside the range, below it.
By their numbers in this assay, from the lowest: compound 3; then compound 1; then compound 2.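

In this assay, (1-isopropylazetidin-3-yl)methoxy in place of ethoxy, on the otherwise unchanged core, gives a 23-fold lower number from compound 2 to compound 3 (1.36 log units; beyond the scatter). This single pair shows that the position on the aromatic ring carrying the oxygen accepts a much larger group, one with a four-membered ring containing nitrogen, and that inhibition becomes stronger rather than merely being retained. Nothing available explains the size of this step.

Still open, on these data alone, is whether the gain depends on the ring nitrogen, the isopropyl or the ring itself. Cyclobutylmethoxy, an azetidine lacking the isopropyl, or a piperidine at this place would separate these.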